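The compounds below may be only part of what the source reports. "The series", "measured", "known", "first", "only" and "open" are said of these compounds alone.

- Compound 1 `COc1ccc(CCCN2CCC(COC(c3ccccc3)c3ccc(Cl)cc3)CC2)cc1`: 200 nM
- Compound 2 `Cc1ccc(CCCN2CCC(COC(c3ccccc3)c3ccccc3)CC2)cc1`: 200 nM

In a functional assay on cells (T-cell line, Homo sapiens) for inhibition (on this read-out lower numbers stand for stronger inhibition and higher numbers for weaker inhibition), compound 1 gives 200 nM and compound 2 gives 200 nM, so compound 2 stands level with compound 1 within the scatter. Compound 3 `CCN1CCC(COC(c2ccccc2)c2ccccc2)CC1` differs from compound 2 as follows: hydrogen in place of 4-methylbenzyl on a saturated chain carbon, two bonds along the chain from an amine nitrogen in a ring. Hydrogen stands in place of 4-methylbenzyl, which amounts to 3-(4-methylphenyl)propyl becoming ethyl. Within the data shown here, no measured pair shows this change, so the expectation is tentative. The step of a 15-fold higher number from compound 2 to compound 3 (1.18 log units; beyond the scatter) is expected to be a weakening of inhibition in this assay, beyond the scatter. For compound 3 the estimated value is 3000 nM, with an expected range of 500 nM to 20000 nM.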

Compound 3, half-maximal inhibitory concentration: > 20000 nM
Compound 3: no number, only a limit; the forecaster's own chance of this, stated with the estimate: 20%; middle value at least 6.6-fold (0.82 log units) from the limit.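

In this assay, the change from 3-(4-methylphenyl)propyl to ethyl gives an at least 100-fold higher number from compound 2 to compound 3 (2.00 log units; beyond the scatter), a large loss of inhibition. Compound 3 gives > 20000 nM, which is a limit of the assay and not a number. This position therefore does not tolerate losing 4-methylbenzyl, something compounds 1 and 2 could not show, as both keep an aryl-bearing chain there.

The step removes chain length and the aromatic ring together, and the compounds shown do not separate the two. As far as these compounds go, how 2-(4-methylphenyl)ethyl, or a plain butyl chain without the ring, would read remains open.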